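Swapping Bromo for Fluoro: Predicting Compound 3

The source may hold more compounds than are shown below. What is called first, only, known or untested is meant among the compounds shown, and "the series" means these compounds.

Compound 1 `NS(=O)(=O)c1ccc(NC(=S)Nc2ccc3ncnc(Nc4ccc(F)c(Br)c4)c3c2)cc1`: 18200 nM
Compound 2 `NS(=O)(=O)c1ccc(NC(=S)Nc2ccc3ncnc(Nc4cccc(Br)c4)c3c2)cc1`: 20700 nM

In a functional assay on A-431 cells (Homo sapiens) for antiproliferative activity, read by MTT assay, with a stated time of 72 h (a higher number here means a weaker inhibitor, a lower number a stronger inhibitor), compound 1 gives 18200 nM. In this assay compound 2 gives 20700 nM. These two numbers sit within the scatter of each other, so neither compound stands apart. Compound 3 `NS(=O)(=O)c1ccc(NC(=S)Nc2ccc3ncnc(Nc4cccc(F)c4)c3c2)cc1` differs from compound 2 by fluoro in place of bromo on an aromatic carbon. Within the data shown here, the only measured step, a 1.1-fold higher number from compound 1 to compound 2 (0.06 log units; within the scatter), touched a different group and stayed within the scatter, so no measured step speaks directly to this change. A modest step is therefore expected: a 1.4-fold higher number from compound 2 to compound 3 (0.16 log units; within the scatter). Compound 3 is estimated at 30000 nM, within a range from 12000 nM to 80000 nM.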

Compound 3, half-maximal inhibitory concentration: 30100 nM
Compound 3: the middle estimate sits 1.0-fold (0.00 log units) below what was measured, within the range that was stated.
By their numbers in this assay, from the lowest: compounds 1, 2 and 3 (each within the scatter of the next).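

In this assay, exchanging bromo for fluoro on this aromatic carbon gives a 1.5-fold higher number from compound 2 to compound 3 (0.16 log units; within the scatter) and stays within the scatter, so this halogen swap brings no readable shift. Going to 3-fluorophenyl from 3-bromo-4-fluorophenyl gives a 1.7-fold higher number from compound 1 to compound 3 (0.22 log units; within the scatter) and also stays within the scatter, so even this wider change leaves the number readably unmoved. Nothing available explains why these values stay so close. On these data alone, whether an amine, a methoxy group or a carboxylic acid in this place would move the number beyond the scatter remains open.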